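Compound 3: A Group Change at the Assay Limit

A few compounds are considered here, and "the series" means these few. Any claim that something is new, unique, unknown or untested is made for them only; others in the source may bear on it.

- Compound 1 `Cc1ccc(C2=NN(c3ccc(S(C)(=O)=O)cc3)C(=O)CC2)cc1`: > 100000 nM, a limit
- Compound 2 `Cc1cc(O)ccc1C1=NN(c2ccc(S(C)(=O)=O)cc2)C(=O)CC1`: > 100000 nM, a limit

Both results come from a functional assay on EKVX cells (Homo sapiens) for inhibition, read by sulforhodamine B assay, with a stated time of 48 h; a lower number here means a stronger inhibitor of growth, a higher number a weaker inhibitor of growth. Neither is a true number, and compound 2 has only a limit to its name: > 100000 nM. The measurements so far come down to the limit of > 100000 nM in this assay, at which 2 of the 2 values shown sit.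

Compound 3 `CCc1ccc(C2=NN(c3ccc(S(C)(=O)=O)cc3)C(=O)CC2)cc1` has not yet been measured. It carries 4-ethylphenyl in place of 4-hydroxy-2-methylphenyl on a carbon with a double bond to nitrogen. The group that enters has no hydrogen-bond donor or acceptor, while the group that leaves has one of each.

Within the data shown here, only one measured step bears on this change: a step that the two limits leave unreadable from compound 1 to compound 2. It also swaps the group at this place, but it gives no size to build on. With compound 2 at > 100000 nM, no step beyond the scatter is expected in this assay, and no direction can be favoured.

The expected step is a number no higher from compound 2 to compound 3 (the limit leaves the size open).

Compound 3 is estimated at 100000 nM, with an expected range of 40000 nM to 150000 nM.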

Compound 3, concentration for total growth inhibition: 96700 nM
For compound 3 the middle estimate is 1.0-fold (0.01 log units) above the measured one, within the range that was stated.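

In this assay, among these compounds, compound 3 gives 96700 nM, the first true number in this set, which shows that a group on this carbon with a double bond to nitrogen can give a readable value. Swapping the group gives an at least 1.0-fold lower number from compound 2 to compound 3 (0.01 log units; that floor lies within the scatter), and adding a methyl to the chain of compound 1 gives an at least 1.0-fold lower number from compound 1 to compound 3 (0.01 log units; that floor lies within the scatter); both floors lie within the scatter, so neither step shows a real gain, and the step between the two limit compounds cannot be read. The readable value also shows that 4-ethylphenyl, with 0 hydrogen-bond donors and 0 hydrogen-bond acceptors, is enough to leave the limit, though most of the set still stops at that limit: the limit of > 100000 nM in this assay, at which 2 of the 3 values shown sit.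

On these data alone, it remains open whether a longer chain, such as 4-propylphenyl in place of 4-ethylphenyl, would give a step beyond the scatter. As far as these compounds go, it is equally open what an amine or a carboxylic acid on the phenyl ring would do to the concentration for total growth inhibition.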